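From 4-methoxyphenyl to 4-chlorophenyl: compound 3 to compound 4

The source may report more compounds than this note shows. Statements on the series, on what has been measured and on what is new or still open speak of the compounds shown alone.

In a functional assay on HCT-15 cells (Homo sapiens) for cytotoxicity (on this read-out lower numbers stand for stronger inhibition and higher numbers for weaker inhibition), compound 1 `Cc1ccc2c(O)nc(-c3ccccc3)cc2c1` gives 5130 nM and compound 2 `Cc1ccc2c(O)nc(-c3ccccc3C)cc2c1` gives 30900 nM on the same read-out. Compound 3 `COc1ccc(-c2cc3cc(C)ccc3c(N3CCN(C)CC3)n2)cc1` carries a 4-methoxyphenyl group and gives 9330 nM in this assay on that scale. This value lies within the scatter of the value for compound 1, while the number for compound 2 is higher than that of compound 3 by more than the scatter.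

Compound 4 `Cc1ccc2c(N3CCN(C)CC3)nc(-c3ccc(Cl)cc3)cc2c1` has not yet been measured. It differs from compound 3 in one place chloro in place of methoxy on an aromatic carbon with chloro in place of methoxy on an aromatic carbon, para to a large group.

For the measured compounds named here, no measured step covers this exchange. Going by the values given here, the only measured step is a 6.0-fold higher number from compound 1 to compound 2 (0.78 log units; beyond the scatter) with methyl in place of hydrogen on an aromatic carbon. It shows that one small change moved the number between compound 1 and compound 2, so the range has to stay wide, but it involves a different group and gives no direction here. No shift beyond the scatter is therefore expected.

The expected step is a 1.1-fold lower number from compound 3 to compound 4 (0.04 log units; within the scatter) and it is estimated to stay within the scatter. In this assay compound 4 is expected at 8500 nM (estimated range 3000 nM to 25000 nM).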

Compound 4, half-maximal inhibitory concentration: 6030 nM
Estimate against measurement, compound 4: 1.4-fold (0.15 log units) above; measured number inside the range.
By their numbers in this assay, from the lowest: compounds 1, 4 and 3 (each within the scatter of the next); then compound 2.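

In this assay, for the compounds shown here, replacing methoxy with chloro on an aromatic carbon, para to a large group, gives a 1.5-fold lower number from compound 3 to compound 4 (0.19 log units; within the scatter) and is the first step measured at this place. Here a group with two heavy atoms and one hydrogen-bond acceptor gives way to a single chlorine with no hydrogen-bond acceptor, and the number does not move beyond the scatter, whereas the only earlier step, a 6.0-fold higher number from compound 1 to compound 2 (0.78 log units; beyond the scatter), was a different change and did exceed it. This single pair therefore shows that this position tolerates this particular exchange without a measurable shift in the read-out, but nothing shown explains why.

With only the 4-methoxyphenyl and 4-chlorophenyl groups to compare, the compounds shown leave open whether any other substituent at this place, such as an amine, a carboxylic acid or a longer alkoxy chain, would move the number beyond the scatter. They also leave open whether the same exchange would give a similar result with a hydroxyl group on the shared core in place of the group carried by compound 3 and compound 4.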